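The source may hold more compounds than are shown below. What is called first, only, known or untested is meant among the compounds shown, and "the series" means these compounds.

Measured so far:
compound 1 `COc1cnc(-c2ccccn2)nc1C1CCCC1`: 749 mL/min/kg
compound 2 `COc1cnc(-c2ccccn2)nc1NC1CCCC1`: 210 mL/min/kg
compound 3 `COc1cnc(-c2ccccn2)nc1NCc1ccccc1C`: 55 mL/min/kg

In an in vitro ADME assay on microsomes from liver (Homo sapiens) for metabolic stability, read by LC-MS, tested at 0.05 uM (on this read-out higher numbers stand for fast clearance and lower numbers for slow clearance), compound 3 gives the lowest of the three numbers; compound 2 sits above it and compound 1 further above, both gaps beyond the scatter. Among the compounds with values here, the only step between two measured compounds, a 3.6-fold lower number from compound 1 to compound 2 (0.55 log units; beyond the scatter), concerns another part of the molecule and does not bear on the change now in view. Compound 4 `COc1cnc(-c2ccccn2)nc1NCc1ccccc1F` differs from compound 3 by fluoro in place of methyl on an aromatic carbon, placed on an aromatic carbon of a six-membered aromatic ring of carbon only, ortho to a large group. Within the data shown here, no measured pair shows a swap of this kind, so the expectation rests on compound 3 alone. Relative to compound 3, the step expected for compound 4 in this assay is no change at the digits printed from compound 3 to compound 4 (within the scatter), none beyond the scatter. The estimate for compound 4 is 55 mL/min/kg, within 20 mL/min/kg to 140 mL/min/kg.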

Compound 4, clearance: 61 mL/min/kg
Compound 4: the middle estimate sits 1.1-fold (0.04 log units) below what was measured; measured number inside the range.
By their numbers in this assay, from the lowest: compounds 3 and 4 (each within the scatter of the next); then compound 2; then compound 1.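

In this assay, fluoro in place of methyl on an aromatic carbon, ortho to a large group, gives a 1.1-fold higher number from compound 3 to compound 4 (0.04 log units; within the scatter), so this read-out does not separate 2-methylphenyl from 2-fluorophenyl. The number seen for compound 3 therefore does not require the methyl at this position. Nothing available explains this outcome.
Going by these compounds, whether a larger group such as trifluoromethyl, or a carboxylic acid, would be tolerated equally at this position remains open. So does whether fluoro would behave the same way elsewhere on this ring.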